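This account rests on a few compounds, and the source may have more. Where it says the series, first, only, none or still open, it means among the compounds named here.

Compound 1 `O=C(/C=C/c1ccccc1)N1CCc2c(Cl)c(O)c(O)c(Cl)c2C1` gives 83% in a functional assay (Homo sapiens), tested at 1 uM; a higher number here means a weaker effect of the compound at the concentration tested, a lower number a stronger effect. Compound 2 `O=C(CCCc1ccc(F)cn1)N1CCc2c(Cl)c(O)c(O)c(Cl)c2C1` gives 89%. Compound 3 `O=C(CCCc1ccc([N+](=O)[O-])cn1)N1CCc2c(Cl)c(O)c(O)c(Cl)c2C1` gives 74%.

Compound 3 stands lowest of the three numbers in this assay, although its value and that of compound 1 lie within the scatter of each other. Against compound 2 the difference is clearer: a number 15 percentage points lower from compound 2 to compound 3 (beyond the scatter), a modest step beyond the scatter.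

Compound 4 `N#Cc1ccc(CCCC(=O)N2CCc3c(Cl)c(O)c(O)c(Cl)c3C2)nc1` follows from compound 3 by cyano in place of nitro on an aromatic carbon. For the measured compounds named here, only the step from compound 2 to compound 3 bears on this, since it changed the same position; it was modest. Compound 4 is therefore expected to stay close to compound 3, with a number 4 percentage points higher from compound 3 to compound 4 (within the scatter) not expected to exceed the scatter. Compound 4 is estimated at 78%, in the range 65% to 92%.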

Compound 4, a percentage reported as activity, at one concentration (the size of the read-out at that concentration, not a potency): 86%
Beside the measured number, compound 4's estimate is 8 percentage points below it; low and high end bracket the measured number.
By their numbers in this assay, from the lowest: compounds 3, 1, 4 and 2 (each within the scatter of the next, the first and the last beyond it).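

Going from 5-nitropyridin-2-yl to 5-cyanopyridin-2-yl gives a number 12 percentage points higher from compound 3 to compound 4 (beyond the scatter) in this assay and shows that this aromatic carbon, para to a large group, does not treat nitro and cyano alike. Cyano and fluoro stay together, with a number 3 percentage points lower from compound 2 to compound 4 (within the scatter) and so, of the three groups at this place, only nitro stands apart from the other two. No evidence is given that would explain this difference. Going by these compounds, whether an amine or a carboxylic acid on this carbon would give a lower number than nitro remains open, as does whether nitro keeps its lead with a shorter chain to the amide carbonyl.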